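Chain extension of hydroxamic acids on two cores

This account rests on a few compounds, and the source may have more. Where it says the series, first, only, none or still open, it means among the compounds named here.

Compound 1 `Nc1ncnc2c1c(-c1cnc3[nH]ccc3c1)nn2CCCCCC(=O)NO`: > 150000 nM
Compound 2 `Nc1ncnc2c1c(-c1cnc3[nH]ccc3c1)nn2CCCCCCC(=O)NO`: > 50000 nM
Compound 3 `Nc1nc2cc(-c3nn(CCCCC(=O)NO)c4ncnc(N)c34)ccc2o1`: 29600 nM

All three were tested in a functional assay on PLC-PRF-5 cells (Homo sapiens) for inhibition, read by MTT assay, with a stated time of 72 h; on this read-out higher numbers stand for weaker inhibition and lower numbers for stronger inhibition. Compound 1 reaches only a limit there, > 150000 nM, which is not a number. Compound 2 likewise gives only a limit, > 50000 nM. The change between them is (hydroxycarbamoyl)methyl in place of hydroxycarbamoyl on a saturated chain carbon, five bonds along the chain from an aromatic nitrogen, and the step that the two limits leave unreadable from compound 1 to compound 2 therefore cannot be read because both values sit at limits the limit of > 150000 nM in this assay, at which 1 of the 3 values shown sits (the limit of > 50000 nM in this assay, at which 1 of the 3 values shown sits). Going by the values given here, compound 3 is the one compound with a number in this assay, 29600 nM; how its core differs from that of compound 1 is not broken down here.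

Compound 4 `Nc1nc2cc(-c3nn(CCCCCC(=O)NO)c4ncnc(N)c34)ccc2o1` is not yet measured. It differs from compound 3 by (hydroxycarbamoyl)methyl in place of hydroxycarbamoyl on a saturated chain carbon, four bonds along the chain from an aromatic nitrogen, the same kind of change as from compound 1 to compound 2, though there the group sits five bonds along the chain from an aromatic nitrogen rather than four. Since the earlier step is unreadable, little fixes its size, and a moderate step of a 3.0-fold lower number from compound 3 to compound 4 (0.47 log units; beyond the scatter) is expected. Compound 4 is estimated at 10000 nM, within 2000 nM to 40000 nM.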

Compound 4, half-maximal inhibitory concentration: > 50000 nM
Compound 4: a limit, no number; the forecaster's own chance of this, stated with the estimate: 10%; middle value at least 5.0-fold (0.69 log units) from the limit.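

The exchange of hydroxycarbamoyl for (hydroxycarbamoyl)methyl gives an at least 1.6-fold higher number from compound 3 to compound 4 (0.22 log units; that floor lies within the scatter), so on this core the longer chain brings no gain in this assay, while no loss beyond the scatter is established. Compound 4 gives only a limit, not a number, so this step has only a floor: the limit of > 50000 nM in this assay, at which 2 of the 4 values shown sit. The same change on the core of compound 1 cannot be read, since compound 1 and compound 2 both stand at limits, so the series neither confirms nor refutes that the change acts alike on the two cores.

Open, from the compounds shown here alone, is how far the true value of compound 4 lies from that of compound 3, and how the two cores compare at equal chain length. Also open is what 3-(hydroxycarbamoyl)propyl, a shorter chain than any shown, would give on either core, and what a carboxylic acid in place of hydroxycarbamoyl would give.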